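Same Side-Chain Swap Tried on a Second Core

This account rests on a few compounds, and the source may have more. Where it says the series, first, only, none or still open, it means among the compounds named here.

Compound 1, `CC(C)[C@H](NC(=O)CN(c1nc(Cl)nc2[nH]cnc12)C1CC1)C(=O)OCc1ccccc1`: 55.5%
Compound 2, `CSCC[C@H](NC(=O)CN(c1nc(Cl)nc2[nH]cnc12)C1CC1)C(=O)OCc1ccccc1`: 30.8%
Compound 3, `CSCC[C@H](NC(=O)CN(c1ncnc2c1ncn2C1CCCCO1)C1CC1)C(=O)OCc1ccccc1`: 41%

Of the compounds shown here, three have been measured in a functional assay on the whole organism (Tail, strain ICR) with Mus musculus as the target, in the tail flick test, with a stated time of 60 min, at a dose of 25 umol/kg by the oral route; on this read-out higher numbers stand for a stronger effect at the one dose given and lower numbers for a weaker effect. Compound 1 and compound 2 share one core and differ only in the side chain at the amino-acid position, and here the change isopropyl in place of 2-(methylsulfanyl)ethyl on a saturated chain carbon bound to an amide-type nitrogen and a carbonyl carbon gives a number 24.7 percentage points higher from compound 2 to compound 1 (beyond the scatter). Compound 3 carries a different core; the difference between the core of compound 3 and the core of compound 2 is not broken down here. In this assay compound 3 gives 41%, which stands second among the three, lying beyond the scatter both of compound 2 and of compound 1.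

Compound 4, `CC(C)[C@H](NC(=O)CN(c1ncnc2c1ncn2C1CCCCO1)C1CC1)C(=O)OCc1ccccc1`, has not yet been measured. It is built on the core of compound 3 and differs from compound 3 by isopropyl in place of 2-(methylsulfanyl)ethyl on a saturated chain carbon bound to an amide-type nitrogen and a carbonyl carbon, the same change that was made from compound 2 to compound 1, at the same place. Among the measured compounds shown here, the expected step is a number 21 percentage points higher from compound 3 to compound 4 (beyond the scatter), resting on a number 24.7 percentage points higher from compound 2 to compound 1 (beyond the scatter) as the only example of this change seen so far. Since the change has been observed once, on one core, the range is kept wide. Compound 4 is therefore expected to give about 62% in this assay, between 45% and 80%.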

Compound 4, a percentage reported as activity, at one dose (the size of the read-out at that dose, not a potency): 34.9%
The estimate for compound 4 lay 27.1 percentage points above the measured number, and the stated range ends above it.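

In this assay, placing isopropyl where 2-(methylsulfanyl)ethyl stood on the core of compound 3 gives a number 6.1 percentage points lower from compound 3 to compound 4 (within the scatter), so on this core the swap produces no difference that can be separated from the usual scatter. The clear gain seen on the first core therefore does not carry over to the second, and the size of this change depends on the core that carries it: the same change on two cores in this assay, a number 24.7 percentage points higher (beyond the scatter) from compound 2 to compound 1 and a number 6.1 percentage points lower (within the scatter) from compound 3 to compound 4, 30.8 percentage points apart, beyond the scatter of two such steps. This does not show which feature of the two cores accounts for the gap, since they differ in more than one place, and with a single pair on each core it gives no general rule for how the swap would behave on any further core.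

The compounds shown leave open how an amine, a carboxylic acid or a longer alkyl chain on the same saturated chain carbon, bound to an amide-type nitrogen and a carbonyl carbon, would compare with isopropyl and 2-(methylsulfanyl)ethyl on either core. They also leave open whether the gap between the two steps would hold at other doses or at other times after dosing, as each compound appears here at a single dose and time.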